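This account rests on a few compounds, and the source may have more. Where it says the series, first, only, none or still open, it means among the compounds named here.

In an assay on microsomes from brain for inhibition of Fatty-acid amide hydrolase 1 (Rattus norvegicus), read by fluorescence and HPLC, with a stated time of 60 min (on this read-out higher numbers stand for weaker inhibition and lower numbers for stronger inhibition), compound 1 `CCCCCCCCc1ccc(OCC(=O)Cn2nnc(-c3ccccc3)n2)cc1` gives 24 nM. Compound 2 `CCCCCCCCc1ccc(OCC(=O)Cn2nnc(-c3ccncc3)n2)cc1` gives 24 nM, and compound 3 `CCCCCCCCc1ccc(OCC(=O)Cn2nnc(-c3cccs3)n2)cc1` gives 32 nM. Compound 1 therefore stands level with compound 2, the two of them sharing the lowest of the three numbers, and its furthest companion is compound 3, reached by a 1.3-fold higher number from compound 1 to compound 3 (0.12 log units; within the scatter). The step of no change at the digits printed from compound 1 to compound 2 (within the scatter) and the step of a 1.3-fold higher number from compound 2 to compound 3 (0.12 log units; within the scatter) are equally modest.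

Compound 4 `CCCCCCCCc1ccc(OCC(=O)Cn2nnc(C(=O)O)n2)cc1` differs from compound 1 in a single place: carboxy in place of phenyl on an aromatic carbon. The three measured steps each exchange one aromatic ring for another and none of them moves beyond the scatter, so they suggest that the group at this position can vary somewhat without cost. Among the measured compounds shown here, none of them, however, removes the ring altogether in favour of a carboxy group, so no measured step bears directly on this change, and the expectation has to be broad. The estimate for compound 4 in this assay is 120 nM, with a range from 25 nM to 600 nM. That estimate means an expected step of a 5.0-fold higher number from compound 1 to compound 4 (0.70 log units; beyond the scatter), leaning toward a higher number than the measured steps showed.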

Compound 4, half-maximal inhibitory concentration in the Fatty-acid amide hydrolase 1 assay: 41 nM
For compound 4 the middle estimate is 2.9-fold (0.47 log units) above the measured one; low and high end bracket the measured number.
By their numbers in the Fatty-acid amide hydrolase 1 assay, from the lowest: compounds 1, 2, 3 and 4 (each within the scatter of the next).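

Replacing the ring with a group that has no ring at all still leaves the number within the scatter in the Fatty-acid amide hydrolase 1 assay: the steps are a 1.7-fold higher number from compound 1 to compound 4 (0.23 log units; within the scatter), a 1.7-fold higher number from compound 2 to compound 4 (0.23 log units; within the scatter) and a 1.3-fold higher number from compound 3 to compound 4 (0.11 log units; within the scatter). The earlier compounds shown here all carried an aromatic ring here, so only now is it clear that no such ring is needed at this position for inhibition at this level. In a physicochemical assay for lipophilicity, read by HPLC, tested at 5 mM (on this read-out higher numbers stand for higher lipophilicity and lower numbers for lower lipophilicity), compound 1 gives 8 and compound 4 gives 5.3 there. The same change is large in the physicochemical assay, yet inhibition does not separate from that of compound 1 beyond the scatter: the measured partition coefficient of compound 1, 8, and of compound 4, 5.3, a number 2.70 log units lower (beyond the scatter)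

Still open, from the compounds shown here alone, is whether any group at this position would move the inhibition number beyond the scatter, for instance a primary amide, a methyl ester or an amine. Also open, going by these compounds, is whether carboxy would behave the same way with a shorter chain on the shared core.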